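Chlorine on the allyl ether: lipophilicity notes

This account rests on a few compounds, and the source may have more. Where it says the series, first, only, none or still open, it means among the compounds named here.

Measured compounds in a physicochemical assay for lipophilicity, measured as octanol-water partition; a lower number here means a more polar compound, a higher number a more lipophilic compound:
compound 1 `CCO/N=C/Nc1cc(Cl)c(F)c(Cl)c1` gives 4
compound 2 `CCO/N=C/Nc1cc(Cl)c(OCCCl)c(Cl)c1` gives 4
compound 3 `C#CCc1c(Cl)cc(N/C=N/OCC=C)cc1Cl` gives 3.7

Compound 3 sits within the scatter of compound 1 and of compound 2 in this assay; the three values are indistinguishable on these numbers.

The next compound is compound 4 `C#CCc1c(Cl)cc(N/C=N/OC/C=C\Cl)cc1Cl`. It differs from compound 3 in one place:
2-chloroethenyl in place of vinyl on a saturated chain carbon bound to an oxygen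
Cut one bond further out, the change reads allyloxy to (3-chloroprop-2-en-1-yl)oxy.

Among the measured compounds shown here, only one measured step is available, no change at the digits printed from compound 1 to compound 2 (within the scatter), and it concerns a different change at a different place, so no measured step covers this one directly. It does show that adding a chlorine-bearing chain at a ring carbon left this assay flat here. For compound 4 a small rise beyond the scatter is expected, a number 0.50 log units higher from compound 3 to compound 4 (beyond the scatter), since the change adds one chlorine and no donor or acceptor. The estimate for compound 4 in this assay is 4.2, expected between 3.8 and 4.7.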

Compound 4, partition coefficient: 3.9
The estimate for compound 4 lay 0.30 log units above the measured number; measured number inside the range.
By their numbers in this assay, from the lowest: compounds 3, 4, 1 and 2 (each within the scatter of the next).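

In this assay, among the compounds shown here, the first measured change at this position gives a number 0.20 log units higher from compound 3 to compound 4 (within the scatter) with 2-chloroethenyl in place of vinyl on a saturated chain carbon bound to an oxygen. This step therefore cannot be told apart from no change, and the same holds at a different place for no change at the digits printed from compound 1 to compound 2 (within the scatter) with 2-chloroethoxy in place of fluoro, so neither of the two chlorine-bearing replacements moves the read-out beyond the scatter. No measurement shown here accounts for either flat step.

From the compounds shown here alone, whether an amine, a carboxylic acid or a longer chain in place of 2-chloroethenyl at this position would move the number beyond the scatter remains open. Also open, going by these compounds, is whether the same replacement of vinyl by 2-chloroethenyl would read the same on the core of compound 1.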